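Bromo to iodo on the shared indole-free core: a single swap

The source may report more compounds than this note shows. Statements on the series, on what has been measured and on what is new or still open speak of the compounds shown alone.

Working notes on a small set of thioacrylic acids bearing a bicyclic aromatic core. Compound 1 `O=C(O)/C(S)=C/c1c[nH]c2cc(Br)ccc12` and compound 2 `O=C(O)/C(S)=C/c1c[nH]c2c(F)cccc12` have been measured in an assay on isolated protein for inhibition of Calpain-1 catalytic subunit (Sus scrofa); a higher number here means a weaker inhibitor, a lower number a stronger inhibitor. Compound 1 gives 90 nM; compound 2 gives 110 nM. The two numbers sit within the scatter of each other, so compound 1 has the lowest number of the two without being separated from compound 2 in any meaningful way.

Compound 3 `O=C(O)/C(S)=C/c1c[nH]c2cc(I)ccc12` differs from compound 1 by iodo in place of bromo on an aromatic carbon. For the measured compounds named here, no measured pair in the set shows a comparable exchange, so there is no step to lean on. The expectation for compound 3 is a step of a 1.1-fold lower number from compound 1 to compound 3 (0.05 log units; within the scatter), which is to say none beyond the scatter, with a slight lean toward a lower number. Compound 3 is therefore estimated at 80 nM, with a range from 35 nM to 200 nM.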

Compound 3, half-maximal inhibitory concentration: 300 nM
Beside the measured number, compound 3's estimate is 3.8-fold (0.57 log units) below it; the whole stated range lies below it.
By their numbers in this assay, from the lowest: compounds 1 and 2 (each within the scatter of the next); then compound 3.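

In this assay, for the compounds shown here, iodo in place of bromo on this aromatic carbon gives a 3.3-fold higher number from compound 1 to compound 3 (0.52 log units; beyond the scatter), so the position separates these two groups, something the earlier compounds, with no comparable pair, could not show. The exchange swaps one heavy atom for one heavy atom, with no ring, hydrogen-bond donor, hydrogen-bond acceptor or net charge entering or leaving, and the step still lies beyond the scatter. Nothing in the available data explains this step. The compounds shown leave open whether chloro or methyl on this same carbon would give a number close to that of compound 1 or that of compound 3. A single pair also cannot tell whether the same exchange on another aromatic carbon of the shared core would give a step of similar size.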